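Compound 4: chloro for trifluoromethyl at a limit

The source may hold more compounds than are shown below. What is called first, only, known or untested is meant among the compounds shown, and "the series" means these compounds.

Measured in a functional assay on the whole organism (strain Kunming) with Mus musculus as the target, with a stated time of 0.5 h; on this read-out higher numbers stand for an effect only at larger amounts of compound and lower numbers for an effect already at smaller amounts:
- compound 1 `COc1ccccc1/C=C/C(=O)OC/C=C/c1cc(OC)c(OC)cc1OC`: 780 umol/kg
- compound 2 `COc1cc(OC)c(OC)cc1/C=C/COC(=O)/C=C/c1ccc(Br)cc1`: > 692 umol/kg (a limit)
- compound 3 `COc1cc(OC)c(OC)cc1/C=C/COC(=O)/C=C/c1ccccc1C(F)(F)F`: > 710 umol/kg (a limit)

Compound 3 stands at > 710 umol/kg, which is a limit and not a number. The same holds for (the limit of > 710 umol/kg in this assay, at which 1 of the 3 values shown sits). The limit for compound 2 is the limit of > 692 umol/kg in this assay, at which 1 of the 3 values shown sits.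

Compound 4 `COc1cc(OC)c(OC)cc1/C=C/COC(=O)/C=C/c1ccccc1Cl` carries chloro in place of trifluoromethyl on an aromatic carbon.

Among the compounds with values here, three measured steps bear on this change, and none has a readable size: a step that the limit leaves unreadable from compound 1 to compound 3, a step that the two limits leave unreadable from compound 2 to compound 3 and a step that the limit leaves unreadable from compound 1 to compound 2. Within the data shown here, the only number is for compound 1 at 780 umol/kg, so the expectation rests mainly on that value. No direction can be drawn from these steps, and no step beyond the usual scatter is expected. The expected change is an at least 1.0-fold lower number from compound 3 to compound 4 (0.00 log units; that floor lies within the scatter). For compound 4 the estimated value is 700 umol/kg, with an expected range from 300 umol/kg to 1100 umol/kg.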

Compound 4, dose for half-maximal effect: 639 umol/kg
For compound 4 the middle estimate is 1.1-fold (0.04 log units) above the measured one; measured number inside the range.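

In this assay compound 4 gives 639 umol/kg, a second actual number in the series alongside compound 1. With chloro in place of methoxy on this aromatic carbon, the result is a 1.2-fold lower number from compound 1 to compound 4 (0.09 log units; within the scatter), so this assay does not separate the two groups at this place. Two further readings, an at least 1.1-fold lower number from compound 3 to compound 4 (0.04 log units; that floor lies within the scatter) and an at least 1.0-fold lower number from compound 2 to compound 4 (0.03 log units; that floor lies within the scatter), are floors set by limits and give no size for either change.

The steps among compound 1, compound 2 and compound 3 cannot be read. Going by these compounds, whether an amine or a carboxylic acid on this aromatic carbon would move the number beyond the scatter from compound 4 stays open.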